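The compounds below may be only part of what the source reports. "The series", "measured", "known", "first", "only" and "open" are said of these compounds alone.

Working notes on the sulfone acylguanidine series.

Compound 1 `Cc1cc2c(cc1C(=O)N=C(N)N)S(=O)(=O)CCC2C` is the reference point; in a functional assay for inhibition, with Homo sapiens as the target (on this read-out lower numbers stand for stronger inhibition and higher numbers for weaker inhibition), compound 1 gives 655 nM. Compound 2 `Cc1cc2c(cc1C(=O)N=C(N)N)S(=O)(=O)CCC2` carries hydrogen in place of methyl on a saturated ring carbon, the change (hydrogen in place of methyl on a saturated ring carbon), and in this assay compound 2 gives 14300 nM. The step of a 22-fold higher number from compound 1 to compound 2 (1.34 log units; beyond the scatter) is the only one so far with both ends measured, and it is large.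

Compound 3 `Cc1cc2c(cc1C(=O)N=C(N)N)S(=O)(=O)C(C)C2N` belongs to a different core; the difference between the two cores is not broken down here. In this assay compound 3 gives 2320 nM, which stands between the values of compound 1 and compound 2.

Compound 4 `Cc1cc2c(cc1C(=O)N=C(N)N)S(=O)(=O)CC2N` is not yet measured. It differs from compound 3 by hydrogen in place of methyl on a saturated ring carbon. Among the measured compounds shown here, this is the same kind of change as the one from compound 1 to compound 2, but the surroundings differ: in compound 3 the methyl sits on a five-membered non-aromatic ring with one sulfur, next to the ring sulfur and next to the ring atom that bears an amino group, whereas in compound 1 it sits on a six-membered non-aromatic ring with one sulfur, three ring bonds from the ring sulfur.

For the measured compounds named here, the expectation for compound 4 in this assay is a step of a 7.8-fold higher number from compound 3 to compound 4 (0.89 log units; beyond the scatter), smaller than the earlier one but in the same direction, because the only measured precedent, a 22-fold higher number from compound 1 to compound 2 (1.34 log units; beyond the scatter), was large and the change here lands on a differently placed ring carbon. Compound 4 is therefore estimated at 18000 nM, with a likely range from 4000 nM to 80000 nM.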

Compound 4, half-maximal inhibitory concentration: 692 nM
Estimate against measurement, compound 4: 26-fold (1.42 log units) above; the measured number lies below the stated range.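

The change does not carry over from one core to the other in this assay. On the core of compound 3, hydrogen in place of methyl on a saturated ring carbon gives a 3.4-fold lower number from compound 3 to compound 4 (0.53 log units; beyond the scatter), so the same change runs opposite in direction to the step on the core of compound 1, and the gap between the two steps is beyond what scatter would give: the same change on two cores in this assay, a 22-fold higher number (1.34 log units; beyond the scatter) from compound 1 to compound 2 and a 3.4-fold lower number (0.53 log units; beyond the scatter) from compound 3 to compound 4, 73-fold (1.86 log units) apart, beyond the scatter of two such steps. Among the compounds shown here, this shows that the step measured on one core cannot be used as a guide to the step on the other core, but it rests on only two pairs and does not show which difference between the cores governs the outcome, as ring size, the placing of the methyl relative to the ring sulfur and the presence of the amino group all change together.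

Going by these compounds, it remains open whether the amino group has any part in the reversal, a question that a hydroxyl group or a hydrogen at that ring atom of the five-membered core would address. On these data alone, it is also open how the series responds at the same ring carbon to a longer chain such as ethyl, on either core.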